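This account rests on a few compounds, and the source may have more. Where it says the series, first, only, none or still open, it means among the compounds named here.

In a functional assay on HeLa cells (Homo sapiens) for antiproliferative activity, read by MTT assay, with a stated time of 24 h (a higher number here means a weaker inhibitor, a lower number a stronger inhibitor), compound 3 `O=S(=O)(c1ccccc1)n1c(-c2cn(-c3ccccc3)nc2-c2ccc(F)cc2)nc2ccccc21` gives 680 nM. Compound 1 `Cc1ccc(-c2nn(-c3ccccc3)cc2-c2nc3ccccc3n2S(=O)(=O)c2ccccc2)cc1` gives 820 nM and compound 2 `Cc1ccc(-c2nn(-c3ccccc3)cc2-c2nc3ccccc3n2S(=O)(=O)c2cc(C)ccc2C)cc1` gives 370 nM. The value of compound 3 lies within the scatter of both. Compound 4 `Cc1ccc(C)c(S(=O)(=O)n2c(-c3cn(-c4ccccc4)nc3-c3ccc(F)cc3)nc3ccccc32)c1` differs from compound 3 in one place, on a sulfonyl sulfur, with 2,5-dimethylphenyl in place of phenyl on a sulfonyl sulfur. The same swap has been measured once, as a 2.2-fold lower number from compound 1 to compound 2 (0.35 log units; beyond the scatter), a modest change beyond the scatter. The other measured change, fluoro in place of methyl, is a 1.2-fold lower number from compound 1 to compound 3 (0.08 log units; within the scatter), which stays within the scatter. A similar modest gain is therefore expected here, with an estimated 2.2-fold lower number from compound 3 to compound 4 (0.34 log units; beyond the scatter), though it rests on a single pair. Compound 4 is estimated at 310 nM, with a likely range from 160 nM to 600 nM.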

Compound 4, half-maximal inhibitory concentration: 320 nM
The estimate for compound 4 lay 1.0-fold (0.01 log units) below the measured number, and the stated range covers the measured number.
By their numbers in this assay, from the lowest: compounds 4, 2, 3 and 1 (each within the scatter of the next, the first and the last beyond it).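

In this assay the change from phenyl to 2,5-dimethylphenyl on a sulfonyl sulfur gives a 2.1-fold lower number from compound 3 to compound 4 (0.33 log units; beyond the scatter), so the modest gain first seen on one core repeats on a second: the same change on two cores in this assay, a 2.2-fold lower number (0.35 log units; beyond the scatter) from compound 1 to compound 2 and a 2.1-fold lower number (0.33 log units; beyond the scatter) from compound 3 to compound 4, 1.0-fold (0.02 log units) apart, within the scatter of two such steps. Fluoro in place of methyl on an aromatic carbon again leaves the number within the scatter, with a 1.2-fold lower number from compound 2 to compound 4 (0.06 log units; within the scatter), and this also holds on both cores: the same change on two cores in this assay, a 1.2-fold lower number (0.08 log units; within the scatter) from compound 1 to compound 3 and a 1.2-fold lower number (0.06 log units; within the scatter) from compound 2 to compound 4, 1.0-fold (0.02 log units) apart, within the scatter of two such steps. Across these four compounds, each change therefore reads the same whichever form the other place takes.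

Still open, from the compounds shown here alone, is whether the gain needs both methyl groups. Going by these compounds, how a single methyl, a methoxy or an amine on that ring would compare also remains unknown.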